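From cyclohexyl to 4-hydroxycyclohexyl on the shared core

A few compounds are considered here, and "the series" means these few. Any claim that something is new, unique, unknown or untested is made for them only; others in the source may bear on it.

In a functional assay on PC-3 cells (Homo sapiens) for inhibition, read by sulforhodamine B assay, with a stated time of 72 h (on this read-out lower numbers stand for stronger inhibition and higher numbers for weaker inhibition), compound 1 (`Nc1sc(-c2ccc(Cl)cc2)c(-c2ccc(Cl)cc2)c1C(=O)NC1CCCCC1`) gives 7300 nM as the lowest of the three numbers measured. Compound 2 (`Nc1sc(-c2ccc(Cl)cc2)c(-c2ccc(Cl)cc2)c1C(=O)NC1CCC1`) reads 24800 nM while compound 3 (`CCOC(=O)Nc1sc(-c2ccc(Cl)cc2)c(-c2ccc(Cl)cc2)c1C(=O)NC1CC1`) reads 27600 nM on the same scale. Compound 4 (`Nc1sc(-c2ccc(Cl)cc2)c(-c2ccc(Cl)cc2)c1C(=O)NC1CCC(O)CC1`) differs from compound 1 by hydroxy in place of hydrogen on a saturated ring carbon and so bears 4-hydroxycyclohexyl. Only a 3.4-fold higher number from compound 1 to compound 2 (0.53 log units; beyond the scatter) touches that cyclohexyl group, with cyclobutyl in its place. Going by the values given here, that step is modest yet beyond the scatter, so a modest rise is expected, though no measured step adds a hydroxy group. The estimated step is a 2.1-fold higher number from compound 1 to compound 4 (0.31 log units; beyond the scatter) in this assay on this basis. The expected value for compound 4 is 15000 nM with an estimated range from 6000 nM to 40000 nM overall.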

Compound 4, half-maximal inhibitory concentration: 5670 nM
For compound 4 the middle estimate is 2.6-fold (0.42 log units) above the measured one; measured number below the stated range.
By their numbers in this assay, from the lowest: compounds 4 and 1 (each within the scatter of the next); then compounds 2 and 3 (each within the scatter of the next).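

In this assay, the cyclohexyl group takes hydroxy on a saturated ring carbon with a 1.3-fold lower number from compound 1 to compound 4 (0.11 log units; within the scatter), so the read-out does not separate 4-hydroxycyclohexyl from cyclohexyl. The hydroxy compound also stands clear of the cyclobutyl amide, with a 4.4-fold lower number from compound 2 to compound 4 (0.64 log units; beyond the scatter), as compound 1 does. No measurement shown explains why the added hydroxy leaves the number within the scatter. On these data alone, it remains open whether an amine, a carboxylic acid or a methoxy group on the same ring carbon would read alike, and whether the hydroxy would behave the same way on the cyclobutyl ring.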